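Trifluoromethyl for chloro on the urea phenyl ring

A few compounds are considered here, and "the series" means these few. Any claim that something is new, unique, unknown or untested is made for them only; others in the source may bear on it.

Three ureas sharing one core have been measured in a physicochemical assay for solubility, at pH 7.4; a lower number here means a less soluble compound, a higher number a more soluble compound. Compound 1 `CC(=O)c1ccc(NC(=O)Nc2cc(C)nc3ccccc23)cc1` gives 3800 nM; compound 2 `CSc1ccc(NC(=O)Nc2cc(C)nc3ccccc23)cc1` gives 1300 nM; compound 3 `Cc1cc(NC(=O)Nc2ccc(Cl)cc2)c2ccccc2n1` gives 1400 nM. Compound 3 stands second highest of the three numbers, with compound 2 within the scatter of it and compound 1 the furthest away: the step of a 2.7-fold lower number from compound 1 to compound 3 (0.43 log units; beyond the scatter) is modest, and a 2.9-fold lower number from compound 1 to compound 2 (0.47 log units; beyond the scatter) is of the same size, while a 1.1-fold higher number from compound 2 to compound 3 (0.03 log units; within the scatter) lies within the scatter.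

Compound 4 `Cc1cc(NC(=O)Nc2ccc(C(F)(F)F)cc2)c2ccccc2n1` differs from compound 3 in one place: trifluoromethyl in place of chloro on an aromatic carbon. Going by the values given here, no measured step exchanges chloro for trifluoromethyl, so the expectation rests on the two neighbours of compound 3 alone. The pair of compound 2 and compound 3 shows that replacing one small group on that aromatic carbon by another left this assay essentially unchanged, whereas the larger acetyl gave the highest number. Compound 4 is therefore expected to sit near compound 3 or somewhat lower, a step of a 1.4-fold lower number from compound 3 to compound 4 (0.15 log units; within the scatter), giving an estimated 1000 nM with a range from 400 nM to 2500 nM.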

Compound 4, solubility: 100 nM
Beside the measured number, compound 4's estimate is 10-fold (1.00 log units) above it; measured number outside the range, below it.
By their numbers in this assay, from the lowest: compound 4; then compounds 2 and 3 (each within the scatter of the next); then compound 1.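

Among the earlier compounds, exchanging groups on this aromatic carbon moved the number in this assay only modestly or not beyond the scatter, yet trifluoromethyl in place of chloro gives a 14-fold lower number from compound 3 to compound 4 (1.15 log units; beyond the scatter), a large step. Trifluoromethyl in place of methylsulfanyl is also large, at a 13-fold lower number from compound 2 to compound 4 (1.11 log units; beyond the scatter), and so is trifluoromethyl in place of acetyl, at a 38-fold lower number from compound 1 to compound 4 (1.58 log units; beyond the scatter). The three earlier groups therefore did not mark out the full range at this position, and compound 4 stands lowest of the four, with its steps to all the others beyond the scatter.

Nothing available here accounts for the size of these steps. From the compounds shown here alone, it remains open where an amine, a carboxylic acid or a methoxy group on this carbon would fall in the same assay, and whether trifluoromethyl would produce a step of this size on another core.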